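The source may report more compounds than this note shows. Statements on the series, on what has been measured and on what is new or still open speak of the compounds shown alone.

For the measured compounds named here, compound 2 `Cc1noc(NS(=O)(=O)c2ccc(N/C(S)=N\c3ccnc4cc(C(F)(F)F)ccc34)cc2)c1C` is the only compound of this set with a number in a functional assay on LoVo cells (Homo sapiens) for antiproliferative activity, read by sulforhodamine B assay, with a stated time of 48 h (on this read-out higher numbers stand for weaker inhibition and lower numbers for stronger inhibition), where compound 2 gives 67100 nM. Going by the values given here, its companion compound 1 `Cc1cc(NS(=O)(=O)c2ccc(N/C(S)=N\c3ccnc4cc(C(F)(F)F)ccc34)cc2)on1` is reported in this assay as "not active" (no number reported), without a number, so no step between measured compounds can be drawn. Compound 3 `O=S(=O)(Nc1ncccn1)c1ccc(N/C(S)=N\c2ccnc3cc(C(F)(F)F)ccc23)cc1` differs from compound 2 by pyrimidin-2-yl in place of 3,4-dimethyl-1,2-oxazol-5-yl on a sulfonamide nitrogen, a swap of one small heteroaromatic group for another on the sulfonamide nitrogen while the shared core is untouched. Among the compounds with values here, with only one measured number and one inactive entry, there is no measured change on which to ground a direction. The step from compound 2 to compound 3 is therefore expected to stay within the usual scatter, a 1.1-fold lower number from compound 2 to compound 3 (0.05 log units; within the scatter), with a real chance that compound 3 too is reported only as inactive. Compound 3 is estimated at 60000 nM, within a range of 15000 nM to 200000 nM.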

Compound 3, half-maximal inhibitory concentration: 34700 nM
Compound 3: middle estimate off by 1.7-fold (0.24 log units), on the high side, and the stated range covers the measured number.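

In this assay, pyrimidin-2-yl can take the place of 3,4-dimethyl-1,2-oxazol-5-yl on the sulfonamide nitrogen with a 1.9-fold lower number from compound 2 to compound 3 (0.29 log units; within the scatter). For the compounds shown here, this is the first measured step at this position, and it shows that exchanging a five-membered aromatic ring for a six-membered one, both with 2 hetero atoms, leaves the read-out within the scatter. Nothing on hand offers an explanation for this result.

As far as these compounds go, compound 1 is reported as "not active" (no number reported), so how its group on the sulfonamide nitrogen compares with those of the two measured compounds remains open. Also open, from the compounds shown here alone, is whether a group of a different kind at this position, such as a carboxylic acid, an amine or a longer alkyl chain, would shift the number beyond the scatter.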